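Moving the Chlorine on a Benzoate Ester of a Triterpenoid Core

A few compounds are considered here, and "the series" means these few. Any claim that something is new, unique, unknown or untested is made for them only; others in the source may bear on it.

Measured compounds:
compound 1, `CC1=CC[C@H]2[C@H](CC[C@]2(C)O)C(C)(C)[C@@H]1CC[C@H]1[C@]2(C)CC[C@H](OC(=O)c3ccc(Cl)cc3)C(C)(C)O[C@H]2CC[C@@]1(C)O`: 10300 nM
compound 2, `CC1=CC[C@H]2[C@H](CC[C@]2(C)O)C(C)(C)[C@@H]1CC[C@H]1[C@]2(C)CC/C(=N/OCc3ccccc3)C(C)(C)O[C@H]2CC[C@@]1(C)O`: 38200 nM

The account concerns two esters and one oxime ether sharing the same core. In a functional assay on MDA-MB-231 cells (Homo sapiens) for antiproliferative activity, read by MTT assay, with a stated time of 72 h (a higher number here means a weaker inhibitor, a lower number a stronger inhibitor), compound 1 gives 10300 nM, the lower of the two numbers, and compound 2 gives 38200 nM, a gap that lies beyond the scatter. No pair among these two differs in a single place, so the numbers show only that the chlorinated benzoate of compound 1 is the stronger of the two measured entries.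

Compound 3, `CC1=CC[C@H]2[C@H](CC[C@]2(C)O)C(C)(C)[C@@H]1CC[C@H]1[C@]2(C)CC[C@H](OC(=O)c3ccccc3Cl)C(C)(C)O[C@H]2CC[C@@]1(C)O`, has not been measured. It differs from compound 1 in one place: 2-chlorophenyl in place of 4-chlorophenyl on a carbonyl carbon. The same atoms are present and joined differently, so the change moves the chlorine around the aromatic ring without adding or removing anything. Going by the values given here, compound 1 is the only reference for this change, and nothing among the measured compounds indicates which way such a rearrangement should move the result. Compound 3 is therefore expected to land close to compound 1, with a 1.2-fold higher number from compound 1 to compound 3 (0.07 log units; within the scatter) amounting to no step beyond the scatter. The estimate for compound 3 in this assay is 12000 nM, within a range of 5000 nM to 30000 nM.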

Compound 3, half-maximal inhibitory concentration: 24300 nM
Compound 3: the middle estimate sits 2.0-fold (0.31 log units) below what was measured; low and high end bracket the measured number.
By their numbers in this assay, from the lowest: compound 1; then compounds 3 and 2 (each within the scatter of the next).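

Going by these compounds alone, the step between compound 1 and compound 3 is the first comparison here that changes one place only, and it shows that the position of the chlorine on the benzoate matters: in this assay, 2-chlorophenyl in place of 4-chlorophenyl on a carbonyl carbon gives a 2.4-fold higher number from compound 1 to compound 3 (0.37 log units; beyond the scatter), a modest change with the same atoms present. Compound 2 could not show this, as it differs from compound 1 in more than one place, so the earlier numbers gave only a ranking of two unlike entries; within this pair, the 4-chlorophenyl ester of compound 1 carries the lower number. No measurement available here accounts for the step, which therefore stands as an observation without an assigned cause.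

The compounds shown leave open whether the same dependence on position would appear with bromine or a methoxy group in place of the chlorine, or how a benzoate with no substituent on its ring would compare. Also open, from the compounds shown here alone, is whether an amide in place of the ester oxygen would keep the difference between the 4-chlorophenyl and 2-chlorophenyl groups.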